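The source may hold more compounds than are shown below. What is called first, only, known or untested is meant among the compounds shown, and "the series" means these compounds.

Compound 1 `COc1cccc(N2C(=O)COc3ccc(-c4cnc(Cl)c(NS(=O)(=O)c5ccc(F)cc5)c4)cc32)c1`: > 40000 nM, a limit of the assay
Compound 2 `O=C1COc2ccc(-c3cnc(Cl)c(NS(=O)(=O)c4ccc(F)cc4)c3)cc2N1C1CCCCC1`: > 40000 nM, a limit of the assay
Compound 3 `COc1ncc(-c2ccc3c(c2)N(c2ccccc2)C(=O)CO3)cc1NS(=O)(=O)c1ccc(F)cc1`: 14000 nM

All three were tested in a functional assay on HepG2 cells (Homo sapiens) for antiproliferative activity, read by MTT assay, with a stated time of 72 h; on this read-out lower numbers stand for stronger inhibition and higher numbers for weaker inhibition. Going by the values given here, compound 3 has the only actual number, as the other two results are limits.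

Compound 4 `O=C1COc2ccc(-c3cnc(Cl)c(NS(=O)(=O)c4ccc(F)cc4)c3)cc2N1c1ccccc1` differs from compound 3 at a single place: chloro in place of methoxy on an aromatic carbon. It has chloro in place of methoxy on an aromatic carbon, next to the ring nitrogen.

Among the compounds with values here, no measured step covers this change directly. Within the data shown here, the only measured step is a step that the two limits leave unreadable from compound 1 to compound 2, with cyclohexyl in place of 3-methoxyphenyl on an amide-type nitrogen in a ring, so it offers no size to carry over.

Compound 1 and compound 2 already carry this chloro, and both stand at the limit of > 40000 nM in this assay, at which 2 of the 3 values shown sit. Neither has the phenyl group shared by compound 3 and compound 4, so this is indirect support. A moderate shift toward weaker inhibition in this assay is still expected. The expected change is a 2.5-fold higher number from compound 3 to compound 4 (0.40 log units; beyond the scatter). For compound 4 the estimate is 35000 nM, with an expected range from 12000 nM to 80000 nM.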

Compound 4, half-maximal inhibitory concentration: 35700 nM
Beside the measured number, compound 4's estimate is 1.0-fold (0.01 log units) below it; the range from low to high includes it.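

In this assay, going by these compounds alone, chloro in place of methoxy next to the ring nitrogen gives a 2.6-fold higher number from compound 3 to compound 4 (0.41 log units; beyond the scatter), the first change in this set with a readable size, and a modest one. Methoxy therefore goes with the lower number of this pair, with everything else in the two structures the same. Phenyl in place of cyclohexyl gives an at least 1.1-fold lower number from compound 2 to compound 4 (0.04 log units; that floor lies within the scatter) and hydrogen in place of methoxy gives an at least 1.1-fold lower number from compound 1 to compound 4 (0.04 log units; that floor lies within the scatter), floors within the scatter that show no real difference, because compound 1 and compound 2 stand at a limit rather than a number: the limit of > 40000 nM in this assay, at which 2 of the 4 values shown sit.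

As far as these compounds go, it remains open how an amine, a fluoro or an ethoxy group on this carbon would compare with methoxy. Also open, from the compounds shown here alone, is whether the step from methoxy to chloro keeps its size with cyclohexyl or 3-methoxyphenyl on the amide-type nitrogen.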